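Aryl exchange on the triazole of a spirooxindole series

The compounds below may be only part of what the source reports. "The series", "measured", "known", "first", "only" and "open" are said of these compounds alone.

Compound 1, `N#CC1=C(N)Oc2c(c3nc4ccccc4nc3c3ccccc23)C12C(=O)N(Cc1cnnn1-c1cccc(S(N)(=O)=O)c1)c1ccccc12`, gives 21500 nM in a functional assay on HepG2 cells (Homo sapiens) for antiproliferative activity, read by MTT assay, with a stated time of 48 h; a higher number here means a weaker inhibitor, a lower number a stronger inhibitor.
Compound 2, `Cc1ccc(C)c(-n2nncc2CN2C(=O)C3(C(C#N)=C(N)Oc4c3c3nc5ccccc5nc3c3ccccc43)c3ccccc32)c1`, reaches only the limit > 50000 nM in this assay.
Compound 3, `N#CC1=C(N)Oc2c(N)cc3nc4ccccc4nc3c2C12C(=O)N(Cc1cnnn1-c1cccc(C(F)(F)F)c1)c1ccccc12`, gives 15800 nM in this assay.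

Among the numbers, compound 3 has the lower of the two, with compound 1 nearest; the gap between the two lies within the scatter. Compound 2 sits at the limit of > 50000 nM in this assay, at which 1 of the 3 values shown sits. Going by the values given here, the one step measured so far, an at least 2.3-fold higher number from compound 1 to compound 2 (0.36 log units; beyond the scatter), shows that exchanging the aryl group on the triazole nitrogen can cost activity, but that step removes a group with hydrogen-bond acceptors.

Compound 4, `N#CC1=C(N)Oc2c(N)cc3nc4ccccc4nc3c2C12C(=O)N(Cc1cnnn1-c1ccc(F)c(Cl)c1)c1ccccc12`, differs from compound 3 only in that aryl group: 3-chloro-4-fluorophenyl in place of 3-(trifluoromethyl)phenyl on an aromatic nitrogen. Neither the group that leaves nor the group that enters carries a donor or an acceptor, so the measured step from compound 1 to compound 2 bears on it only loosely. Among the compounds with values here, with no measured step of this kind, a change within the scatter is expected. The estimated step from compound 3 to compound 4 is a 1.1-fold higher number from compound 3 to compound 4 (0.06 log units; within the scatter). Compound 4 is therefore expected to give about 18000 nM in this assay, within a range from 8000 nM to 45000 nM.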

Compound 4, half-maximal inhibitory concentration: > 50000 nM
Compound 4: no number, only a limit; the forecaster's own chance of this, stated with the estimate: 20%; middle value at least 2.7-fold (0.44 log units) from the limit.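

The step, an at least 3.1-fold higher number from compound 3 to compound 4 (0.50 log units; beyond the scatter), shows that the aryl group on this aromatic nitrogen matters even when neither the group that leaves nor the group that enters carries a hydrogen-bond donor or acceptor. The earlier step, an at least 2.3-fold higher number from compound 1 to compound 2 (0.36 log units; beyond the scatter), removed a group with hydrogen-bond acceptors and could not show this, whereas here an exchange between two halogen-bearing phenyl groups, each a single six-membered aromatic ring of carbon only, is enough for a change beyond the scatter. Compound 4 gives only a limit in this assay, not a number, and it shares that limit with compound 2: the limit of > 50000 nM in this assay, at which 2 of the 4 values shown sit.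

The compounds shown leave open which part of the exchange carries the loss, since the trifluoromethyl group leaves while chlorine and fluorine enter together, and a phenyl group bearing only the chlorine or only the fluorine would separate these changes. They also leave open how an amine or a carboxylic acid on this aryl group would read in this assay, and whether any aryl group here gives a clearly lower number than compound 3 does.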